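The source may report more compounds than this note shows. Statements on the series, on what has been measured and on what is new or still open speak of the compounds shown alone.

Measured so far in a functional assay on HGC-27 cells (Homo sapiens) for cytotoxicity, read by MTT assay, with a stated time of 72 h; on this read-out lower numbers stand for stronger inhibition and higher numbers for weaker inhibition:
Compound 1 `COc1ccccc1Nc1nc(SCc2ccc(C(F)(F)F)cc2)nc2ccccc12` gives > 50000 nM, a limit of the assay.
Compound 2 `COc1ccc(Nc2nc(SCc3ccc(C(F)(F)F)cc3)nc3ccccc23)c(OC)c1` gives > 50000 nM, again a limit.
Among the measured compounds shown here, compound 3 `COc1ccc(Nc2nc(SCc3ccc(C(F)(F)F)cc3)nc3ccccc23)cc1OC` gives 17900 nM, the only number in the set.

The change methoxy in place of hydrogen on an aromatic carbon makes a step that the two limits leave unreadable from compound 1 to compound 2; it is unreadable because of the limit of > 50000 nM in this assay, at which 2 of the 3 values shown sit. The cores of compound 1 and compound 3 differ by 3,4-dimethoxyphenyl in place of 2-methoxyphenyl on a nitrogen on an aromatic ring, a change that makes an at least 2.7-fold lower number from compound 1 to compound 3 (0.44 log units; beyond the scatter), and the related step is an at least 2.7-fold lower number from compound 2 to compound 3 (0.44 log units; beyond the scatter). Compound 4 `COc1cc(Nc2nc(SCc3ccc(C(F)(F)F)cc3)nc3ccccc23)cc(OC)c1OC` carries the same kind of change, (methoxy in place of hydrogen on an aromatic carbon), but the place is not the same: in compound 2 the methoxy enters meta to a methoxy group and para to a large group, whereas in compound 4 it enters ortho to a methoxy group, meta to a large group and meta to a methoxy group. With the earlier step unreadable, only a small step is expected, a 1.5-fold lower number from compound 3 to compound 4 (0.17 log units; within the scatter), resting on compound 3 alone at 17900 nM. Compound 4 is estimated at 12000 nM, within 4000 nM to 40000 nM.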

Compound 4, half-maximal inhibitory concentration: 14000 nM
Compound 4: middle estimate off by 1.2-fold (0.07 log units), on the low side, and the stated range covers the measured number.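

In this assay, methoxy in place of hydrogen on an aromatic carbon, ortho to a methoxy group, makes a 1.3-fold lower number from compound 3 to compound 4 (0.11 log units; within the scatter), so on the core of compound 3 the added methoxy gives no change beyond the scatter. The same replacement from compound 1 to compound 2 cannot be read, and the two results cannot be set side by side, because both of those compounds sit at a limit: the limit of > 50000 nM in this assay, at which 2 of the 4 values shown sit.

Whether this change carries from one core to another therefore remains unshown, with one readable case only. Open, from the compounds shown here alone, is whether an amine or a carboxylic acid at that place on the ring would move the number beyond the scatter from compound 3.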